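Chloro substitution on an indolyl thiourea and peroxidase activity

This account rests on a few compounds, and the source may have more. Where it says the series, first, only, none or still open, it means among the compounds named here.

Measured compounds:
- compound 1, `Oc1ccccc1NC(=S)Nc1ccc2[nH]ccc2c1`, gives 43.9%
- compound 2, `Oc1ccc(NC(=S)Nc2ccc3[nH]ccc3c2)cc1Cl`, gives 39.9%
- compound 3, `Oc1cc(Cl)ccc1NC(=S)Nc1ccc2[nH]ccc2c1`, gives 58.9%

All three compounds were tested in an ADME assay on isolated protein for inhibition of peroxidase (Raphanus sativus), read by fluorescence and Amplex Red, tested at 5 uM; on this read-out lower numbers stand for a stronger effect and higher numbers for a weaker effect at the one concentration tested. Compound 1 and compound 2 share the same thiourea link to the same indole part and differ in the phenol ring; the difference between these two cores is not broken down here. Their values lie within the scatter of each other, so no order can be read from them. Compound 3 is derived from compound 1 by chloro in place of hydrogen on an aromatic carbon, and this step gave a number 15 percentage points higher from compound 1 to compound 3 (beyond the scatter).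

Compound 4, `Oc1c(Cl)cc(NC(=S)Nc2ccc3[nH]ccc3c2)cc1Cl`, has not yet been measured in this assay. It is derived from compound 2 by chloro in place of hydrogen on an aromatic carbon. Going by the values given here, this is the same kind of change as the one from compound 1 to compound 3, but not the same: in compound 3 the entering chloro is meta to a hydroxy group and para to a large group, whereas in compound 4 it is ortho to a hydroxy group, meta to a chloro group and meta to a large group. Among the compounds with values here, the only guide available is the single measured step of this kind, so the expectation rests on the step from compound 1 to compound 3, a number 15 percentage points higher from compound 1 to compound 3 (beyond the scatter), and carries wide uncertainty. Compound 4 is therefore expected to show a number 10.1 percentage points higher from compound 2 to compound 4 (beyond the scatter), a shift of the same direction. The estimate for compound 4 is 50%, with an expected range from 37% to 64%.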

Compound 4, a percentage reported as activity, at one concentration (the size of the read-out at that concentration, not a potency): 48.7%
The estimate for compound 4 lay 1.3 percentage points above the measured number; measured number inside the range.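

In this assay, the added chloro gave a number 8.8 percentage points higher from compound 2 to compound 4 (within the scatter), which means that this step alone cannot be told apart from the ordinary spread of repeated measurements. Set beside the earlier step, it shows no measurable difference between the two cores in how they respond to this change: the same change on two cores in this assay, a number 15 percentage points higher (beyond the scatter) from compound 1 to compound 3 and a number 8.8 percentage points higher (within the scatter) from compound 2 to compound 4, 6.2 percentage points apart, within the scatter of two such steps. Going by these compounds alone, both steps point the same way, but this does not establish a reliable effect of a fixed size that can be carried to other cores: only two pairs are available, one of the two steps lies within the scatter, and in compound 4 the chloro enters ortho to a hydroxy group, a different place from the one it takes in compound 3.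

The compounds shown leave open whether another group in the same places on the phenol ring, such as fluoro, methoxy or an amine, would behave like chloro, and whether the hydroxy group itself matters for the read-out. They also leave open what a urea link in place of the thiourea would do, and how the effect would look at any concentration other than the one tested.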